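Sec-butyl in Place of Isobutyl on an Amine Nitrogen

The source may report more compounds than this note shows. Statements on the series, on what has been measured and on what is new or still open speak of the compounds shown alone.

The measured compounds, read in a functional assay for inhibition, read by spectrophotometry, with a stated time of 30 min, tested at 1 uM; on this read-out higher numbers stand for more inhibition at the one concentration tested (going by the name of the read-out) and lower numbers for less inhibition:

Compound 1 `CCC(C)NC(=C\C(=O)/C=C/c1ccc(O)c(OC)c1)/C=C/c1ccc(O)c(OC)c1` gives 0.13%.
Compound 2 `COc1cc(/C=C/C(=O)/C=C(/C=C/c2ccc(OC(C)=O)c(OC)c2)NCC(C)C)ccc1OC(C)=O` gives 0%.
Compound 3 `COc1cc(/C=C/C(=O)/C=C(/C=C/c2ccc(O)c(OC)c2)NCC(C)C)ccc1O` gives 0.09%.

All three numbers sit close to zero, and no one of them can be called different from another within the usual scatter. Compound 3 and compound 1 differ in one place only, (sec-butyl in place of isobutyl on an amine nitrogen), and this change gave a number 0 percentage points higher from compound 3 to compound 1 (within the scatter) in this assay. Compound 2 and compound 3 differ in more than that: the difference between the two cores is not broken down here, and what can be said is that both gave essentially no inhibition.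

Compound 4 `CCC(C)NC(=C\C(=O)/C=C/c1ccc(OC(C)=O)c(OC)c1)/C=C/c1ccc(OC(C)=O)c(OC)c1` is not yet measured. It differs from compound 2 by sec-butyl in place of isobutyl on an amine nitrogen, the same change as from compound 3 to compound 1, and the place of the change is described in the same words in both cases. Because the earlier change gave a number 0 percentage points higher from compound 3 to compound 1 (within the scatter), the expected step is a number 0.1 percentage points higher from compound 2 to compound 4 (within the scatter) in this assay. Compound 4 is therefore estimated at 0.1%, expected between 0% and 4%.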

Compound 4, a percentage reported as inhibition, at one concentration (the size of the read-out at that concentration, not a potency): 0%
Beside the measured number, compound 4's estimate is 0.1 percentage points above it; low and high end bracket the measured number.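

In this assay, putting sec-butyl in place of isobutyl on an amine nitrogen of the core of compound 2 gave no change at the digits printed from compound 2 to compound 4 (within the scatter). Set side by side, the same change on the two cores gives steps that agree: the same change on two cores in this assay, a number 0 percentage points higher (within the scatter) from compound 3 to compound 1 and no change at the digits printed (within the scatter) from compound 2 to compound 4, 0 percentage points apart, within the scatter of two such steps This shows that the change moves the reading by nothing that can be told apart from scatter on either core, but all four compounds read close to zero, so the agreement is only between two steps of almost no size, and it does not show that the change would carry over in the same way on a core that gives clear inhibition.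

The compounds shown leave open whether any group on this nitrogen can lift the reading away from zero at the one concentration tested. A longer chain, a cyclohexyl group or a chain ending in a carboxylic acid on that amine nitrogen would be a further test of this.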